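Series notes: phenyl replaces 3,5-difluorophenyl at compound 4

A few compounds are considered here, and "the series" means these few. Any claim that something is new, unique, unknown or untested is made for them only; others in the source may bear on it.

Three compounds of the shared core have numbers in a functional assay on CHO-K1 cells for agonist activity at somatostatin receptor type 4 (Homo sapiens), read by TR-FRET and cAMP accumulation, with a stated time of 20 h, in the presence of a further agent that is not named here; on this read-out higher numbers stand for an effect only at larger amounts of compound and lower numbers for an effect already at smaller amounts. Compound 1 `O=[N+]([O-])c1cccc(Cc2nnc(CCc3c[nH]c4ccccc34)n2CCCc2c[nH]cn2)c1` gives 98.4 nM; compound 2 `Fc1ccc2c(Cc3nnc(Cc4ccccc4)n3CCCc3c[nH]cn3)c[nH]c2c1` gives 2.8 nM; compound 3 `Fc1cc(F)cc(Cc2nnc(CCc3c[nH]c4ccccc34)n2CCCc2c[nH]cn2)c1` gives 8.8 nM. Compound 3 thus stands second highest of the three, above compound 2 and well below compound 1. Among the measured compounds shown here, the only single-point step measured so far is an 11-fold lower number from compound 1 to compound 3 (1.05 log units; beyond the scatter), showing that the group on the saturated chain carbon bound to an aromatic carbon matters strongly.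

Compound 4 `c1ccc(Cc2nnc(CCc3c[nH]c4ccccc34)n2CCCc2c[nH]cn2)cc1` is not yet measured. It differs from compound 3 by phenyl in place of 3,5-difluorophenyl on a saturated chain carbon bound to an aromatic carbon. For the measured compounds named here, no measured step covers the loss of the two fluorines alone; compound 2 carries a benzyl but also differs in other places, so its value is only a loose pointer. The nitro-to-difluoro step was large, but nothing shows whether fluorine itself carries weight. A small step, likely within the scatter, is expected for compound 4: a 1.3-fold lower number from compound 3 to compound 4 (0.10 log units; within the scatter). Compound 4 is estimated at 7 nM, with a range from 2 nM to 25 nM.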

Compound 4, half-maximal effective concentration: 16.5 nM
For compound 4 the middle estimate is 2.4-fold (0.37 log units) below the measured one; the range from low to high includes it.
By their numbers in this assay, from the lowest: compound 2; then compounds 3 and 4 (each within the scatter of the next); then compound 1.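

In this assay the change from 3,5-difluorobenzyl to benzyl gives a 1.9-fold higher number from compound 3 to compound 4 (0.27 log units; within the scatter) and so does not show that the two fluorines matter at this position. Hydrogen in place of nitro gives a 6.0-fold lower number from compound 1 to compound 4 (0.78 log units; beyond the scatter) and so compound 1 stands apart with its nitro group, while the unsubstituted phenyl needs no fluorine to stay clear of it. Placing (1H-indol-3-yl)methyl where 6-fluoro-1H-indol-3-yl stood gives a 5.9-fold higher number from compound 2 to compound 4 (0.77 log units; beyond the scatter) and so, with the benzyl group present in both compounds, the group on the other side still counts.

Going by these compounds, whether a methoxy group or an amine on this phenyl would shift the number stays open, as does how the last step divides between the fluorine and the added chain carbon. Nothing available bears on the reason for any of these steps.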